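The source may hold more compounds than are shown below. What is called first, only, known or untested is meant among the compounds shown, and "the series" means these compounds.

Values in a functional assay for inhibition, with Homo sapiens as the target (a higher number here means weaker binding, a lower number tighter binding), for the series:
compound 1 `N#Cc1ccc(C2OCC(C/C=C\CCC(=O)O)C(c3cccnc3)O2)cc1` gives 1290 nM
compound 2 `O=C(O)CC/C=C\CC1COC(c2ccc([N+](=O)[O-])cc2)OC1c1cccnc1` gives 933 nM
compound 3 `O=C(O)CC/C=C\CC1COC(c2cccnc2)OC1c1cccnc1` gives 759 nM

Compound 3 is not separated from the other two, and the three values form one group. The measured steps are a 1.2-fold lower number from compound 2 to compound 3 (0.09 log units; within the scatter) and a 1.7-fold lower number from compound 1 to compound 3 (0.23 log units; within the scatter). Compound 4 `O=C(O)CC/C=C\CC1COC(c2ccco2)OC1c1cccnc1` carries furan-2-yl in place of pyridin-3-yl on a saturated ring carbon, between two ring oxygen atoms: furan-2-yl in place of pyridin-3-yl on a saturated ring carbon. The two steps above changed this same carbon, with pyridin-3-yl replacing 4-nitrophenyl and 4-cyanophenyl, and neither went beyond the scatter. The remaining step, a 1.4-fold lower number from compound 1 to compound 2 (0.14 log units; within the scatter), also stayed within it. No five-membered aromatic ring has been measured at this carbon, so the evidence is indirect. No step beyond the scatter is therefore expected in this assay. The expected step is a 1.2-fold higher number from compound 3 to compound 4 (0.07 log units; within the scatter). For compound 4 the estimated value is 900 nM, with an expected range of 400 nM to 2000 nM.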

Compound 4, dissociation constant: 1260 nM
The estimate for compound 4 lay 1.4-fold (0.15 log units) below the measured number; measured number inside the range.
By their numbers in this assay, from the lowest: compounds 3, 2, 4 and 1 (each within the scatter of the next).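

Notes on the saturated ring carbon between two ring oxygen atoms, in this assay: furan-2-yl, the first five-membered aromatic ring at this carbon, stays within the scatter of all three six-membered aromatic groups (a 1.7-fold higher number from compound 3 to compound 4 (0.22 log units; within the scatter)) and (a 1.4-fold higher number from compound 2 to compound 4 (0.13 log units; within the scatter)) and (a 1.0-fold lower number from compound 1 to compound 4 (0.01 log units; within the scatter)). Across compounds 1 to 4, this carbon therefore tolerates a change of ring size, and of the ring hetero atom from nitrogen to oxygen, with no step beyond the scatter. No measurement at hand accounts for these four values lying together.

Still open, as far as these compounds go, is whether a saturated group such as cyclohexyl, or a phenyl ring carrying an amine, at this carbon would give a step beyond the scatter. Also open, from the compounds shown here alone, is how the number responds to changes at the pyridin-3-yl group or the 5-carboxypent-2-en-1-yl group, both shared by all four compounds.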